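The source may report more compounds than this note shows. Statements on the series, on what has been measured and on what is new or still open speak of the compounds shown alone.

Working notes on the series.

Compound 3 `Cc1ccc(C2=NN(c3nc(-c4ccccc4)cs3)C(c3cccs3)C2)cc1` has, in a functional assay on WM 266-4 cells (Homo sapiens) for antiproliferative activity, read by MTT assay, with a stated time of 48 h (a higher number here means a weaker inhibitor, a lower number a stronger inhibitor), the second highest number of the three measured, giving 7520 nM. Compound 1 `Fc1ccc(C2=NN(c3nc(-c4ccc(C(F)(F)F)cc4)cs3)C(c3cccs3)C2)cc1` gives 5120 nM in this assay, which is within the scatter of compound 3; compound 2 `Cc1ccc(C2=NN(c3nc(-c4ccc(Br)cc4)cs3)C(c3cccs3)C2)cc1` gives 18400 nM, the highest number of the set.

Compound 4 `Cc1ccc(C2=NN(c3nc(-c4ccc(C(F)(F)F)cc4)cs3)C(c3cccs3)C2)cc1` differs from compound 3 by trifluoromethyl in place of hydrogen on an aromatic carbon.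

Among the compounds with values here, one measured step bears directly on this change: a 2.4-fold lower number from compound 2 to compound 3 (0.39 log units; beyond the scatter), where a bromo at the same position leaves and a hydrogen enters. Reversing the direction, putting a substituent back onto that position, would be read as a modest rise in the number. Compound 1 carries the same trifluoromethyl on the same ring, yet its number sits within the scatter of compound 3; compound 1 differs from compound 3 in a second place as well, so its value cannot be read as a clean step.

On balance a modest rise in the number, or none beyond the scatter, is expected, as a 1.3-fold higher number from compound 3 to compound 4 (0.12 log units; within the scatter). Compound 4 is therefore estimated at 10000 nM in this assay, with a range from 4500 nM to 22000 nM.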

Compound 4, half-maximal inhibitory concentration: 2110 nM
For compound 4 the middle estimate is 4.7-fold (0.68 log units) above the measured one; measured number below the stated range.
By their numbers in this assay, from the lowest: compound 4; then compounds 1 and 3 (each within the scatter of the next); then compound 2.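

In this assay, within the data shown here, the only earlier step at this position, bromo to hydrogen, left open whether a substituent there could do anything but raise the number; a 3.6-fold lower number from compound 3 to compound 4 (0.55 log units; beyond the scatter) shows that trifluoromethyl on the same aromatic carbon lowers it, beyond the scatter. The effect of a substituent at this position therefore depends on which group it is, not merely on one being present: exchanging one group for the other gives an 8.7-fold lower number from compound 2 to compound 4 (0.94 log units; beyond the scatter) and is the largest step among the compounds shown, with hydrogen in compound 3 giving a number that falls short of neither extreme. With trifluoromethyl held fixed, a change in the second place also counts, since methyl in place of fluoro gives a 2.4-fold lower number from compound 1 to compound 4 (0.38 log units; beyond the scatter) and so separates two compounds that the earlier comparison with compound 3 could not tell apart.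

From the compounds shown here alone, whether an amine, a carboxylic acid or a methoxy group at this position would follow trifluoromethyl or bromo stays open, as does whether the trifluoromethyl gain carries over to the fluoro series. Nothing on hand gives a reason for any of these differences.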